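This account rests on a few compounds, and the source may have more. Where it says the series, first, only, none or still open, it means among the compounds named here.

Working notes on the series. Two compounds have numbers in an assay on cells for inhibition of ubiquitin carboxyl-terminal hydrolase isozyme L5 (Homo sapiens), read by fluorescence, with a stated time of 30 min; on this read-out higher numbers stand for weaker inhibition and lower numbers for stronger inhibition. Compound 1 `CC(=O)Nc1cccc(-c2cn(Cc3cc(C(=O)O)cc(-c4ccccc4C(=O)O)c3)nn2)c1` gives 96200 nM in this assay, and compound 2 `CC(C(=O)O)c1ccc(C(=O)c2cccc(-c3ccccc3C(=O)O)c2)s1` gives 89100 nM. These two numbers sit within the usual scatter of each other, so neither compound can be set apart from the other; both lie at the weak end of what this read-out reports, and compound 1 carries the larger of the two figures only by a margin that repeated measurement would not resolve.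

Compound 3 `CC(=O)Nc1ccc(-c2cn(Cc3cc(C(=O)O)cc(-c4ccccc4C(=O)O)c3)nn2)cc1` has not yet been measured. It keeps the core of compound 1 and differs from it in one place: 4-acetamidophenyl in place of 3-acetamidophenyl on an aromatic carbon. Within the data shown here, no measured pair shows a change of this kind, so there is no precedent for the size of the step. With compound 1 at 96200 nM as the only anchor, the expected step is a 1.1-fold lower number from compound 1 to compound 3 (0.03 log units; within the scatter), none beyond the scatter in either direction. Compound 3 is therefore estimated at 90000 nM, within 40000 nM to 200000 nM, with a fair chance that this assay returns only a limit at the top of its range rather than a number.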

Compound 3, half-maximal inhibitory concentration: 80900 nM
The estimate for compound 3 lay 1.1-fold (0.05 log units) above the measured number, and the stated range covers the measured number.
By their numbers in this assay, from the lowest: compounds 3, 2 and 1 (each within the scatter of the next).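

In this assay, 4-acetamidophenyl in place of 3-acetamidophenyl on an aromatic carbon of the five-membered aromatic ring with 3 nitrogen gives a 1.2-fold lower number from compound 1 to compound 3 (0.08 log units; within the scatter). Among these compounds, this is the first pair that differs in one place, and it shows no resolved effect of where the acetamido group sits on the phenyl ring at this position. The two isomers cannot be told apart on this read-out and both remain at its weak end, and no independent measurement bears on this result.

The compounds shown carry only acetamidophenyl at this place, so they do not show whether the position responds to any change at all. On these data alone, an amine or a carboxylic acid in place of the acetamido group, or a longer chain in place of its acetyl part, would test whether a step beyond the scatter can be reached here, and the answer remains open, as does the contribution of either carboxylic acid on the shared core.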